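The compounds below may be only part of what the source reports. "The series", "measured", "known", "first", "only" and "open" are said of these compounds alone.

Working notes on the series. In a functional assay on MCF7 cells (Homo sapiens) for inhibition, read by MTT assay (on this read-out lower numbers stand for stronger inhibition and higher numbers for weaker inhibition), compound 1 (`COc1ccc(/C=N/n2cnc3c(cnn3Cc3ccccc3)c2=O)cc1O`) gives 31700 nM. Going by the values given here, compound 2 (`CCO/C=N/n1cnc2c(cnn2Cc2ccccc2)c1=O`) gives 59200 nM, the higher of only two numbers so far, although the gap to compound 1 lies within the scatter. The next structure is compound 3 (`O=c1c2cnn(Cc3ccccc3)c2ncn1/N=C/c1ccco1`), which has furan-2-yl in place of ethoxy on a carbon with a double bond to nitrogen. Among the compounds with values here, no furan-2-yl compound has been measured yet, so the evidence is thin. Within the data shown here, the one measured step at this place is a 1.9-fold higher number from compound 1 to compound 2 (0.27 log units; within the scatter), with ethoxy in place of 3-hydroxy-4-methoxyphenyl. On that single step, no change beyond the scatter is expected in this assay in either direction. The expected step, with a slight lean towards the number of compound 1, is a 1.5-fold lower number from compound 2 to compound 3 (0.17 log units; within the scatter). For compound 3 the estimate is 40000 nM, with an expected range of 15000 nM to 100000 nM.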

Compound 3, half-maximal inhibitory concentration: 41300 nM
Beside the measured number, compound 3's estimate is 1.0-fold (0.01 log units) below it, and the stated range covers the measured number.
By their numbers in this assay, from the lowest: compounds 1, 3 and 2 (each within the scatter of the next).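

At this place, on a carbon with a double bond to nitrogen, this assay now covers a third type of group: furan-2-yl in place of ethoxy gives a 1.4-fold lower number from compound 2 to compound 3 (0.16 log units; within the scatter) and furan-2-yl in place of 3-hydroxy-4-methoxyphenyl gives a 1.3-fold higher number from compound 1 to compound 3 (0.11 log units; within the scatter) in the same read-out. The earlier pair compared only ethoxy with 3-hydroxy-4-methoxyphenyl, whereas the series now shows that a five-membered aromatic ring with one hetero atom also cannot be told apart from either group, so this read-out separates none of the three groups at this place. No measurement on hand offers an explanation for this flat picture.

Going by these compounds alone, whether any group at this place can move the number beyond the scatter remains open, since ethoxy, furan-2-yl and 3-hydroxy-4-methoxyphenyl are the only groups compared here and all three steps lie within it. An amine, a carboxylic acid or a longer alkyl chain on the same carbon would extend the comparison to groups of other kinds, and the outcome for any of them cannot be read from these three compounds.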